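This account rests on a few compounds, and the source may have more. Where it says the series, first, only, none or still open, it means among the compounds named here.

Measured compounds:
compound 1, `Cc1nc2ccc(CNc3ccc(C(=O)N[C@@H](CCC(=O)O)C(=O)O)cc3F)cc2c(=O)[nH]1`, 9340 nM
compound 2, `Cc1nc2ccc(CN(CCN)c3ccc(C(=O)N[C@@H](CCC(=O)O)C(=O)O)c(F)c3)cc2c(=O)[nH]1`, 11700 nM

In an assay on isolated protein for inhibition of Thymidylate synthase (Mus musculus) (a lower number here means a stronger inhibitor, a higher number a weaker inhibitor), compound 1 gives the lower of the two numbers, but compound 2 stands so close that the two values lie within the usual scatter, and no order between them can be read. Compound 2 also differs from compound 1 in more than one place, so nothing about any single change can be drawn from that pair.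

Compound 3, `CCN(Cc1ccc2nc(C)[nH]c(=O)c2c1)c1ccc(C(=O)N[C@@H](CCC(=O)O)C(=O)O)cc1F`, has not yet been measured. It differs from compound 1 in one place: ethyl in place of hydrogen on a nitrogen on an aromatic ring. Among the compounds with values here, no measured pair shows the effect of a group on that nitrogen alone, so the size of the step from compound 1 to compound 3 is uncertain. The account expects a modest decrease in the number, that is a somewhat stronger inhibitor, rather than a change within the scatter, with the step expected to be a 3.7-fold lower number from compound 1 to compound 3 (0.57 log units; beyond the scatter). For compound 3 the estimated value in this assay is 2500 nM, with a range from 600 nM to 9000 nM.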

Compound 3, half-maximal inhibitory concentration: 680 nM
Estimate against measurement, compound 3: 3.7-fold (0.57 log units) above; measured number inside the range.
By their numbers in this assay, from the lowest: compound 3; then compounds 1 and 2 (each within the scatter of the next).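

In this assay, within the data shown here, the nitrogen on an aromatic ring proves to be a place where a small change counts: ethyl in place of hydrogen gives a 14-fold lower number from compound 1 to compound 3 (1.14 log units; beyond the scatter) and this large step is the first single change in the set whose effect can be read. Compound 2 also carries a chain on that nitrogen, but it differs from both compound 1 and compound 3 in more than one place, so its step cannot be read and the result holds for ethyl alone, not for substitution on that nitrogen in general. No measurement at hand explains the size of this step.

The compounds shown leave open how the number would move with a methyl group on that nitrogen, with a longer chain such as propyl, or with a chain ending in a hydroxyl group or a carboxylic acid, and so whether ethyl is close to the best choice there. They also leave open whether ethyl would bring a step of similar size with the fluorine placed as in compound 2.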